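The source may report more compounds than this note shows. Statements on the series, on what has been measured and on what is new or still open speak of the compounds shown alone.

In an ADME assay on microsomes from liver (Rattus norvegicus) for metabolic stability, read by LC-MS, using NADPH, at 37 degrees C (a higher number here means that the compound lasts longer, a lower number that the compound disappears faster), compound 1 `Cc1cccc(C)c1-c1nc(CN2CCC(C(=O)NCCCN3C[C@H](C)C[C@H](C)C3)CC2)c(C)o1` gives 0.0517 h. Compound 2 `Cc1ccc(-c2nc(CN3CCC(C(=O)NCCCN4C[C@H](C)C[C@H](C)C4)CC3)c(C)o2)c(C)c1` gives > 0.5 h, which is a limit of the assay and not a number. Compound 3 `COc1ccc(-c2nc(CN3CCC(C(=O)NCCCN4C[C@H](C)C[C@H](C)C4)CC3)c(C)o2)cc1OC` keeps the shared core but carries 3,4-dimethoxyphenyl in place of 2,4-dimethylphenyl on an aromatic carbon. Within the data shown here, the one measured step that bears on this change is an at least 9.6-fold higher number from compound 1 to compound 2 (0.98 log units; beyond the scatter), made by putting 2,4-dimethylphenyl in place of 2,6-dimethylphenyl on that same carbon. Among the measured compounds shown here, that step lies beyond the scatter, so the group at this place can clearly matter, but no compound measured so far carries 3,4-dimethoxyphenyl. The expected change is an at least 2.5-fold lower number from compound 2 to compound 3 (0.39 log units; beyond the scatter), a modest fall in half-life, and this remains an uncertain expectation. For compound 3 the estimated half-life is 0.2 h, with a range from 0.06 h to 0.5 h.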

Compound 3, half-life: > 0.5 h
Compound 3 was reported as a limit (the forecaster's own chance of this, stated with the estimate: 25%); middle value at least 2.5-fold (0.39 log units) away from the limit.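

In this assay, putting 3,4-dimethoxyphenyl in place of 2,6-dimethylphenyl gives an at least 9.6-fold higher number from compound 1 to compound 3 (0.98 log units; beyond the scatter), so the rise first seen with 2,4-dimethylphenyl at this place is not confined to that one group. The rise appears with methyl groups on the aromatic ring and also with methoxy groups, and compound 1, with 2,6-dimethylphenyl, is the only one of the three with a value that can be read as a number. The step between compound 2 and compound 3 cannot be read, because both compounds sit at the same limit of the assay: the limit of > 0.5 h in this assay, at which 2 of the 3 values shown sit.

Going by these compounds, how long compound 2 and compound 3 actually last therefore stays open. Also open, on these data alone, is whether the half-life stays long with an unsubstituted phenyl ring, a pyridine ring or a phenyl ring carrying a carboxylic acid.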